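Chain aryl swap in the enone-imidazolone series

A few compounds are considered here, and "the series" means these few. Any claim that something is new, unique, unknown or untested is made for them only; others in the source may bear on it.

Two compounds of the series carry numbers in a functional assay on OVCAR-4 cells (Homo sapiens) for inhibition; a higher number here means a weaker inhibitor of growth, a lower number a stronger inhibitor of growth. Compound 1 `COc1cc(/C=C/C(=O)c2cccc(-n3cc(-c4ccccc4)[nH]c3=O)c2)cc(OC)c1OC` gives 1880 nM in this assay. Compound 2 `COc1ccc(-c2cn(-c3cccc(C(=O)/C=C/c4ccc(O)c(OC)c4)c3)c(=O)[nH]2)cc1` gives 6080 nM in this assay, the higher of the two numbers, and the gap down to compound 1 lies beyond the usual scatter. Among the compounds with values here, compound 1 and compound 2 differ in two places at once, so no single step between measured compounds can be read from them.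

Compound 3 `COc1ccc(-c2cn(-c3cccc(C(=O)/C=C/c4cc(OC)c(OC)c(OC)c4)c3)c(=O)[nH]2)cc1` is not yet measured. It differs from compound 2 by 3,4,5-trimethoxyphenyl in place of 4-hydroxy-3-methoxyphenyl on a double-bonded chain carbon bound to a double-bonded chain carbon and keeps the rest of compound 2 unchanged. Within the data shown here, the entering group is the one compound 1 carries on a double-bonded chain carbon bound to a double-bonded chain carbon, which gives a reason to expect a downward step in this assay, because compound 1 gives 1880 nM while compound 2 gives 6080 nM. The expected step is a 2.4-fold lower number from compound 2 to compound 3 (0.39 log units; beyond the scatter), modest but beyond the scatter, with the second difference to compound 1 left unresolved. Compound 3 is therefore estimated at 2500 nM in this assay, within a range of 900 nM to 7000 nM.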

Compound 3, concentration for 50% growth inhibition: 3570 nM
For compound 3 the middle estimate is 1.4-fold (0.15 log units) below the measured one, and the stated range covers the measured number.
By their numbers in this assay, from the lowest: compounds 1, 3 and 2 (each within the scatter of the next, the first and the last beyond it).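

In this assay, within the data shown here, the swap to 3,4,5-trimethoxyphenyl in place of 4-hydroxy-3-methoxyphenyl on a double-bonded chain carbon bound to a double-bonded chain carbon gives a 1.7-fold lower number from compound 2 to compound 3 (0.23 log units; within the scatter) and so provides the first single-place reading at this position, where the change of chain aryl group does not separate the two compounds. Methoxy in place of hydrogen on an aromatic carbon gives a 1.9-fold higher number from compound 1 to compound 3 (0.28 log units; within the scatter) and is likewise not separated, so the gap between compound 1 and compound 2, which lies beyond the scatter and cannot be read as a single step, divides into two steps that each stay within it. No measurement beyond these growth-inhibition numbers bears on the reason for either step.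

Still open, from the compounds shown here alone, is whether the two changes act independently, which would need 4-hydroxy-3-methoxyphenyl on the chain of the core of compound 1 with hydrogen in place of methoxy. Also open, going by these compounds, is whether a different group on the chain aryl ring, such as an amine or a carboxylic acid, would give a step beyond the scatter at this position.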